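Benzylamino in place of morpholin-4-yl on a carbonyl carbon

The source may hold more compounds than are shown below. What is called first, only, known or untested is meant among the compounds shown, and "the series" means these compounds.

Of the compounds shown here, three built on a shared core have been measured in a functional assay on U-937 cells (Homo sapiens) for antiproliferative activity, read by MTT assay, with a stated time of 24 h; a higher number here means a weaker inhibitor, a lower number a stronger inhibitor. Compound 1 (`CCCCNC(=O)CCCOc1ccc(C(=O)c2c(CCCC)oc3ccccc23)cc1`) gives 24600 nM, compound 2 (`CCCCc1oc2ccccc2c1C(=O)c1ccc(OCCCC(=O)N2CCCC2)cc1`) gives 7500 nM, and compound 3 (`CCCCc1oc2ccccc2c1C(=O)c1ccc(OCCCC(=O)N2CCOCC2)cc1`) gives 21400 nM. The measured steps fix where compound 3 stands: there is a 1.1-fold lower number from compound 1 to compound 3 (0.06 log units; within the scatter), and there is a 2.9-fold higher number from compound 2 to compound 3 (0.46 log units; beyond the scatter). Its number therefore sits level with that of compound 1 and clear of that of compound 2.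

Compound 4 (`CCCCc1oc2ccccc2c1C(=O)c1ccc(OCCCC(=O)NCc2ccccc2)cc1`) carries benzylamino in place of morpholin-4-yl on a carbonyl carbon. For the measured compounds named here, no measured step makes this exact exchange. The nearest guide is the step between butylamino and morpholin-4-yl, a 1.1-fold lower number from compound 1 to compound 3 (0.06 log units; within the scatter), as benzylamino, like butylamino, keeps the amide hydrogen. A caution comes from the pyrrolidin-1-yl group, with a 3.3-fold lower number from compound 1 to compound 2 (0.52 log units; beyond the scatter), which shows that a change at this carbonyl carbon can move the number modestly, so the range is kept wide. In this assay the expected change is a 1.4-fold lower number from compound 3 to compound 4 (0.15 log units; within the scatter), and no step beyond the scatter is expected. Compound 4 is estimated at 15000 nM, with an expected range from 6000 nM to 35000 nM.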

Compound 4, half-maximal inhibitory concentration: 15800 nM
The estimate for compound 4 lay 1.1-fold (0.02 log units) below the measured number, and the stated range covers the measured number.
By their numbers in this assay, from the lowest: compound 2; then compounds 4, 3 and 1 (each within the scatter of the next).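

In this assay, benzylamino brings an aromatic ring to this carbonyl carbon, yet the exchange for morpholin-4-yl gives a 1.4-fold lower number from compound 3 to compound 4 (0.13 log units; within the scatter) and the exchange of propyl for phenyl within the amide chain gives a 1.6-fold lower number from compound 1 to compound 4 (0.19 log units; within the scatter); neither step separates the compounds, so this ring leaves the number level with those of compound 1 and compound 3. Pyrrolidin-1-yl, by contrast, remains apart, with a 2.1-fold higher number from compound 2 to compound 4 (0.32 log units; beyond the scatter), and compound 2 now has the lowest number of the four, with its steps to each of the others beyond the scatter. Nothing available explains why pyrrolidin-1-yl alone stands clear of the other three groups at this position.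

The compounds shown leave open whether this separation belongs to pyrrolidin-1-yl alone or extends to piperidin-1-yl or to a small open amine such as dimethylamino. They also leave open how a free carboxylic acid at this carbonyl carbon, or a phenethylamino group with its longer chain to the phenyl ring, would read in this assay.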